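This account rests on a few compounds, and the source may have more. Where it says the series, first, only, none or still open, it means among the compounds named here.

Within the data shown here, compound 1 `O=C(CCCCCCNC(=O)C(O)(O)C(F)(F)F)Nc1ccccc1` is the one member of this set with a number rather than a limit: in a functional assay on HCT-116 cells (Homo sapiens) for inhibition, read by colorimetric assay, with a stated time of 3 days (a lower number here means a stronger inhibitor, a higher number a weaker inhibitor), compound 1 gives 9140 nM. Compound 2 `CC(=O)C(=O)NCCCCCCC(=O)Nc1ccccc1` reaches only a limit of the assay, > 100000 nM. Compound 3 `C/C(=N\O)C(=O)NCCCCCCC(=O)Nc1ccccc1` likewise reaches only a limit, > 100000 nM. The two steps from compound 1, an at least 10-fold higher number from compound 1 to compound 2 (1.03 log units; beyond the scatter) and an at least 10-fold higher number from compound 1 to compound 3 (1.03 log units; beyond the scatter), both swap the group on the carbonyl carbon, and both end at the limit of > 100000 nM in this assay, at which 2 of the 3 values shown sit. Compound 4 `O=C(CCCCCCNC(=O)C(O)(O)C(F)(F)F)Nc1ccc(Cl)cc1` differs from compound 1 at another place: chloro in place of hydrogen on an aromatic carbon. Among the measured compounds shown here, no measured step touches this place, so none of them bears on the change; the two recorded steps concern the carbonyl carbon alone. With nothing comparable to draw on, the expectation is for no movement beyond the scatter, a 1.0-fold lower number from compound 1 to compound 4 (0.01 log units; within the scatter). For compound 4 the estimate is 9000 nM, between 3000 nM and 27000 nM.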

Compound 4, half-maximal inhibitory concentration: 4230 nM
Compound 4: middle estimate off by 2.1-fold (0.33 log units), on the high side; the range from low to high includes it.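

In this assay, among these compounds, the step from hydrogen to chloro gives a 2.2-fold lower number from compound 1 to compound 4 (0.33 log units; beyond the scatter) and shows that this place on the six-membered aromatic ring, which no earlier step touched, can shift the read-out. The shift is modest, and it was obtained with the group on the carbonyl carbon of compound 1 left in place. Nothing available here bears on the reason for this shift.

From the compounds shown here alone, whether fluoro, methoxy or a carboxylic acid at this place would act like chloro remains open. So does whether the 4-chlorophenyl group would lift the acetyl of compound 2 from its limit.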